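Changing the Aryl Group on the Saturated Chain Carbon

A few compounds are considered here, and "the series" means these few. Any claim that something is new, unique, unknown or untested is made for them only; others in the source may bear on it.

Compound 3 `Cc1oc2c([C@H]3CCN(C)C[C@H]3O)c(O)cc(O)c2c(=O)c1C(O)c1ccc(Cl)cc1` gives the highest of the three numbers in a functional assay on MIA PaCa-2 cells (Homo sapiens) for inhibition, read by MTT assay, with a stated time of 48 h, tested at 10 uM (a higher number here means more inhibition of growth at the concentration tested, a lower number less inhibition of growth), with 15%, though the other two lie within the usual scatter of it. Compound 1 `Cc1cc(=O)c2c(O)cc(OCc3ccc(Br)cc3)c([C@H]3CCN(C)C[C@H]3O)c2o1` gives 13% in this assay, and compound 2 `Cc1cc(=O)c2c(O)cc(OCc3ccc([N+](=O)[O-])cc3)c([C@H]3CCN(C)C[C@H]3O)c2o1` gives 12%. Compound 4 `CCOc1ccc(Br)c(C(O)c2c(C)oc3c([C@H]4CCN(C)C[C@H]4O)c(O)cc(O)c3c2=O)c1` is not yet measured; it differs from compound 3 by 2-bromo-5-ethoxyphenyl in place of 4-chlorophenyl on a saturated chain carbon bound to an aromatic carbon and an oxygen on a saturated carbon. Within the data shown here, the only measured step, a number 1 percentage points lower from compound 1 to compound 2 (within the scatter), exchanges one aromatic substituent for another at a different place and is within the scatter. Among the measured compounds shown here, no measured step touches the aryl group that changes here, and all three numbers sit close together, so no step beyond the scatter is expected in this assay. Compound 4 is therefore estimated at 15% in this assay, with a range from 5% to 27%. This expected value means no change at the digits printed from compound 3 to compound 4 (within the scatter).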

Compound 4, percent growth inhibition at one concentration: 4%
Estimate against measurement, compound 4: 11 percentage points above, and the stated range ends above it.
By their numbers in this assay, from the lowest: compounds 4, 2, 1 and 3 (each within the scatter of the next, the first and the last beyond it).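

In this assay, the aryl group on the saturated chain carbon bound to an aromatic carbon and an oxygen on a saturated carbon can move the number: 2-bromo-5-ethoxyphenyl in place of 4-chlorophenyl gives a number 11 percentage points lower from compound 3 to compound 4 (beyond the scatter), the only step shown beyond the scatter. Nothing available explains this lower number.

Because bromo and ethoxy enter together, the compounds shown do not separate their contributions. Also open, on these data alone, is how an aryl group carrying an amine or a carboxylic acid would read at this position.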